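Adding a third ring nitrogen to the amide aryl group

This account rests on a few compounds, and the source may have more. Where it says the series, first, only, none or still open, it means among the compounds named here.

Compound 2 `O=C(Nc1ccc2[nH]ncc2c1)[C@H]1CCCN1C(=O)C1(c2cccc(Cl)c2)CCCC1` gives 1 nM in an assay on isolated protein for inhibition of histone acetyltransferase p300 (Homo sapiens), with a stated time of 60 min (a higher number here means a weaker inhibitor, a lower number a stronger inhibitor), the lowest of the two numbers shown. Compound 1 `O=C(Nc1cnc2[nH]ncc2c1)[C@H]1CCCN1C(=O)C1(c2cccc(Cl)c2)CCCC1` gives 15.9 nM in this assay, and the step of a 16-fold lower number from compound 1 to compound 2 (1.20 log units; beyond the scatter) is the only one measured. Within the data shown here, compound 3 `O=C(Nc1ccc2[nH]nnc2c1)[C@H]1CCCN1C(=O)C1(c2cccc(Cl)c2)CCCC1` carries a different change, (a group of 9 heavy atoms (6 carbon, 3 nitrogen; one five-membered aromatic ring with 3 hetero atoms, one six-membered aromatic ring of carbon only) in place of a group of 9 heavy atoms (7 carbon, 2 nitrogen; one five-membered aromatic ring with 2 hetero atoms, one six-membered aromatic ring of carbon only), on an amide-type nitrogen), which no measured step mirrors directly. Because the one shown step, a 16-fold lower number from compound 1 to compound 2 (1.20 log units; beyond the scatter), came with an extra ring nitrogen, a loss is expected here too, and the estimated step is a 5.0-fold higher number from compound 2 to compound 3 (0.70 log units; beyond the scatter). Compound 3 is therefore expected to give 5 nM, within 1 nM to 30 nM.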

Compound 3, half-maximal inhibitory concentration: 20 nM
Compound 3: the middle estimate sits 4.0-fold (0.60 log units) below what was measured; the measured number falls inside the stated range.
By their numbers in this assay, from the lowest: compound 2; then compounds 1 and 3 (each within the scatter of the next).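

In this assay, the 1H-indazol-5-yl group on the amide-type nitrogen also proves sensitive to an added nitrogen in its five-membered ring, with a 20-fold higher number from compound 2 to compound 3 (1.30 log units; beyond the scatter) as a large loss. Where that extra nitrogen lies makes no clear difference among the groups shown, as a 1.3-fold higher number from compound 1 to compound 3 (0.10 log units; within the scatter) stays small. Nothing available bears on what lies behind this result. As far as these compounds go, whether a methyl group or fluorine on the 1H-indazol-5-yl group would preserve the low number remains open, as does the effect of a simple amine on that ring.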